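Benzyl in place of (thiophen-2-yl)carbonyl on an amine nitrogen

The source may hold more compounds than are shown below. What is called first, only, known or untested is meant among the compounds shown, and "the series" means these compounds.

In a functional assay on HCT-116 cells (Homo sapiens) for antiproliferative activity, read by WST assay, with a stated time of 72 h (on this read-out higher numbers stand for weaker inhibition of growth and lower numbers for stronger inhibition of growth), compound 1 (`N#Cc1ccc(CN[C@H]2[C@@H]3CN(c4ncc(C(=O)NO)cn4)C[C@@H]32)cc1`) gives 270 nM and compound 2 (`O=C(NO)c1cnc(N2C[C@@H]3[C@H](C2)[C@H]3NC(=O)c2cccs2)nc1`) gives 3600 nM as the higher of the two numbers, a gap beyond the usual scatter. Compound 3 (`O=C(NO)c1cnc(N2C[C@@H]3[C@H](C2)[C@H]3NCc2ccccc2)nc1`) differs from compound 2 in one place (benzyl in place of (thiophen-2-yl)carbonyl on an amine nitrogen) with benzyl in place of (thiophen-2-yl)carbonyl on an amine nitrogen, so that ((thiophen-2-yl)carbonyl)amino becomes benzylamino. Among the measured compounds shown here, no measured pair shows this change on its own, so the expectation is indirect. It rests on compound 1 at 270 nM as the closest measured comparison, since its amine nitrogen also carries a benzyl group, there bearing a nitrile. The expected move is a 9.0-fold lower number from compound 2 to compound 3 (0.95 log units; beyond the scatter) toward stronger inhibition of growth and beyond the scatter. In this assay the estimate for compound 3 is 400 nM with a range of 150 nM to 1100 nM expected for it.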

Compound 3, concentration for 50% growth inhibition: 120 nM
Compound 3: the middle estimate sits 3.3-fold (0.52 log units) above what was measured; measured number below the stated range.
By their numbers in this assay, from the lowest: compound 3; then compound 1; then compound 2.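

On the amine nitrogen, this assay now gives a direct reading of this change: benzyl in place of (thiophen-2-yl)carbonyl produces (a 30-fold lower number from compound 2 to compound 3 (1.48 log units; beyond the scatter)), larger than the earlier indirect comparison suggested. Hydrogen in place of cyano on an aromatic carbon gives (a 2.3-fold lower number from compound 1 to compound 3 (0.35 log units; beyond the scatter)), so the nitrile is not required for activity at this level in the benzyl series. Nothing in the data at hand accounts for either step. As far as these compounds go, the first step replaces the ring and removes the carbonyl together, so which of the two carries the gain remains open; a benzoyl or a (thiophen-2-yl)methyl group on the same nitrogen would separate them. From the compounds shown here alone, how a longer chain, such as phenethyl, would read at this nitrogen also remains open.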